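The source may hold more compounds than are shown below. What is called first, only, known or untested is meant among the compounds shown, and "the series" means these compounds.

Compound 1 `Cc1ccc2nc(C(=O)Nc3c(F)cc(-c4cccc(F)c4)cc3F)c(C)c(O)c2c1` gives 3.04% in a functional assay on A-375 cells (Homo sapiens) for antiproliferative activity, read by MTT assay, with a stated time of 24 h, tested at 1.23 ug/mL; a higher number here means a stronger effect of the compound at the concentration tested, a lower number a weaker effect. Compound 2 `CCc1ccc2nc(C(=O)Nc3c(F)cc(-c4cccc(F)c4)cc3F)c(C)c(O)c2c1` gives 12.3% in this assay. The change here is hydrogen in place of methyl on a saturated chain carbon bound to an aromatic carbon, and its step is a number 9.3 percentage points lower from compound 2 to compound 1 (within the scatter). Compound 3 `CCOc1ccc2nc(C(=O)Nc3c(F)cc(-c4cccc(F)c4)cc3F)c(C)c(C(=O)O)c2c1` gives 26.7% in this assay; the difference between the core of compound 3 and the core of compound 2 is not broken down here, and the values place compound 3 beyond the scatter over compound 2 and compound 1. Compound 4 `COc1ccc2nc(C(=O)Nc3c(F)cc(-c4cccc(F)c4)cc3F)c(C)c(C(=O)O)c2c1` awaits measurement in this assay. The change is hydrogen in place of methyl on a saturated chain carbon bound to an oxygen on an aromatic ring, the same kind of change as that from compound 2 to compound 1, though the place differs: there the saturated chain carbon is bound to an aromatic carbon, here to an oxygen on an aromatic ring. A step of similar size is expected, a number 8.7 percentage points lower from compound 3 to compound 4 (within the scatter), because the earlier step of a number 9.3 percentage points lower from compound 2 to compound 1 (within the scatter) stayed within the scatter. Compound 4 is estimated at 18% in this assay.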

Compound 4, a percentage reported as inhibition, at one concentration (the size of the read-out at that concentration, not a potency): 10.2%
The estimate for compound 4 lay 7.8 percentage points above the measured number; the measured number falls inside the stated range.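

Ethoxy to methoxy on the core of compound 3 gives a number 16.5 percentage points lower from compound 3 to compound 4 (beyond the scatter) in this assay. Set beside ethyl to methyl on the other core, the two steps cannot be told apart: the same change on two cores in this assay, a number 9.3 percentage points lower (within the scatter) from compound 2 to compound 1 and a number 16.5 percentage points lower (beyond the scatter) from compound 3 to compound 4, 7.2 percentage points apart, within the scatter of two such steps. This allows the change to be carried between these two cores, but it rests on a single pair per core, with the saturated chain carbon bound to an aromatic carbon in one and to an oxygen on an aromatic ring in the other, and does not establish a fixed step size for the series.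

On these data alone, a longer chain such as propoxy, or an amine at the same place, remains open. Whether either would extend the link between chain and read-out cannot be told from the compounds shown.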